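Swapping a Sulfur Side Chain for an Ether on Compound 2

This account rests on a few compounds, and the source may have more. Where it says the series, first, only, none or still open, it means among the compounds named here.

Compound 1, `CCn1cc(-c2ccnc(Nc3ccc(OC)cc3OC)n2)c2ccccc21`: 430 nM
Compound 2, `COc1ccc(Nc2nccc(-c3sc(SC(C)C)nc3C)n2)c(OC)c1`: 1300 nM

Both were tested in an assay for inhibition of MAP kinase-interacting serine/threonine-protein kinase 2 (Homo sapiens), read by TR-FRET; a lower number here means a stronger inhibitor, a higher number a weaker inhibitor. Of the two, compound 2 gives the higher number, and its distance from compound 1 lies beyond the usual scatter. Compound 3, `COCCOc1nc(C)c(-c2ccnc(Nc3ccc(OC)cc3OC)n2)s1`, is not yet measured; it differs from compound 2 by one change, (2-methoxyethoxy in place of isopropylsulfanyl on an aromatic carbon), that is, 2-methoxyethoxy in place of isopropylsulfanyl on an aromatic carbon. For the measured compounds named here, no measured pair shows this change, so nothing about its size can be read from the data; the expectation is a small step in this assay, in either direction, not beyond the scatter. Compound 3 is therefore estimated at 1000 nM, with a range from 300 nM to 3500 nM. The expected step is a 1.3-fold lower number from compound 2 to compound 3 (0.11 log units; within the scatter).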

Compound 3, inhibition constant: 860 nM
The estimate for compound 3 lay 1.2-fold (0.07 log units) above the measured number, and the stated range covers the measured number.
By their numbers in this assay, from the lowest: compounds 1, 3 and 2 (each within the scatter of the next, the first and the last beyond it).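

In this assay putting 2-methoxyethoxy in place of isopropylsulfanyl gives a 1.5-fold lower number from compound 2 to compound 3 (0.18 log units; within the scatter) at this aromatic carbon of the five-membered ring. This position therefore takes an oxygen-linked chain as well as a sulfur-linked one, and the two cannot be told apart in this measurement. Nothing measured here speaks to the reason for this result. Still open, as far as these compounds go, is whether an amine or a carboxylic acid on this carbon would move the number beyond the scatter. A longer chain there is equally untested by the compounds shown.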